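Swapping a Piperidine for a Piperazine on a Shared Core

This account rests on a few compounds, and the source may have more. Where it says the series, first, only, none or still open, it means among the compounds named here.

Compound 1 `N#Cc1cc2sc3cc(N4CCCCC4)ccc3c2n2c1nc1ccccc12` is the most lipophilic of the compounds measured here. In a physicochemical assay for lipophilicity, read by HPLC, at pH 2.7 (a lower number here means a more polar compound, a higher number a more lipophilic compound), compound 1 gives 8.52, the higher of the two numbers in hand. Compound 2 `N#Cc1c(N2CCNCC2)c2sc3ccccc3c2n2c1nc1ccccc12` carries a piperazine on a different carbon of the same core, and in this assay compound 2 gives 1.08, far lower and well beyond the scatter. In this assay compound 3 `CC(C)CNc1ccc2c(c1)sc1c(NCC(C)C)c(C#N)c3nc4ccccc4n3c12` gives "not determined" (no result reported), so no result was reported for it. Compound 4 `N#Cc1cc2sc3cc(N4CCNCC4)ccc3c2n2c1nc1ccccc12` differs from compound 1 in one place: piperazin-1-yl in place of piperidin-1-yl on an aromatic carbon. Replacing piperidin-1-yl by piperazin-1-yl is expected to move the value in this assay strongly downward, a step well beyond the scatter, though less than the whole gap to compound 2, which sits elsewhere. For compound 4 the expected result is 3.5, between 1.5 and 5.5, an expected step of a number 5.02 log units lower from compound 1 to compound 4 (beyond the scatter).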

Compound 4, distribution coefficient: 0.84
Estimate against measurement, compound 4: 2.66 log units above; measured number below the stated range.
By their numbers in this assay, from the lowest: compounds 4 and 2 (each within the scatter of the next); then compound 1.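

In this assay, placing piperazin-1-yl where piperidin-1-yl stood on this aromatic carbon gives a number 7.68 log units lower from compound 1 to compound 4 (beyond the scatter) even though both groups are six-membered non-aromatic rings. Within the data shown here, the earlier compounds offered no pair differing in one place, so this is the first large step that can be tied to a single group on the shared core. Nothing measured here explains the size of this step.

Open, as far as these compounds go, is whether morpholin-4-yl or 4-methylpiperazin-1-yl on this carbon would stand nearer compound 1 or compound 4. Also open, from the compounds shown here alone, is whether the same exchange elsewhere on the core would give a similar step.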